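The source may report more compounds than this note shows. Statements on the series, on what has been measured and on what is new or still open speak of the compounds shown alone.

Compound 1 `COC(=O)CC(=O)N1N=C(c2ccc(N3CCN(C)CC3)cc2)CC1c1ccc(N(C)C)cc1` and compound 2 `COC(=O)CC(=O)N1N=C(c2ccc(-n3cncn3)cc2)CC1c1ccc(N(C)C)cc1` share one core and differ on the aromatic carbon: in a functional assay on HCC1806 cells (Homo sapiens) for inhibition, read by sulforhodamine B assay, tested at 10 uM (a lower number here means less inhibition, a higher number more inhibition at the concentration tested (going by the name of the read-out)), compound 1 gives -8.3%, and compound 2 gives -7.8%. The step of a number 0.5 percentage points higher from compound 1 to compound 2 (within the scatter) is within the scatter, so the two sit at the same level; compound 2 holds the higher of the two numbers, but that order carries no weight.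

Compound 3 `CN(C)c1ccc(C2CC(c3ccc(-n4cncn4)cc3)=NN2S(C)(=O)=O)cc1` has not yet been tested. Relative to compound 2 the change is methylsulfonyl in place of ((methoxycarbonyl)methyl)carbonyl on an amine nitrogen in a ring. For the measured compounds named here, no measured step touches the group on the ring nitrogen; the only step in hand, a number 0.5 percentage points higher from compound 1 to compound 2 (within the scatter), concerns the aromatic carbon and was flat. With both measured values near zero inhibition, no step beyond the scatter is expected for a number 4.8 percentage points higher from compound 2 to compound 3 (within the scatter), and the estimate for compound 3 in this assay is -3%, in the range -22% to 18%.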

Compound 3, a percentage reported as inhibition, at one concentration (the size of the read-out at that concentration, not a potency): 10.8%
Compound 3: middle estimate off by 13.8 percentage points, on the low side; measured number inside the range.
By their numbers in this assay, from the lowest: compounds 1 and 2 (each within the scatter of the next); then compound 3.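

In this assay, for the compounds shown here, the group on the amine nitrogen in a ring is the first place where a change moves the number beyond the scatter: a number 18.6 percentage points higher from compound 2 to compound 3 (beyond the scatter), with methylsulfonyl in place of ((methoxycarbonyl)methyl)carbonyl. The step at the aromatic carbon, a number 0.5 percentage points higher from compound 1 to compound 2 (within the scatter), stayed flat, so this nitrogen is the only one of the two places to respond so far, and that rests on a single pair carrying the 1H-1,2,4-triazol-1-yl group. Nothing in hand accounts for this step.

The compounds shown leave open whether the rise belongs to the sulfonyl link or to the loss of the ester chain, a question that an acetyl group or a longer alkylsulfonyl chain on the same nitrogen would address. Also open, going by these compounds, is whether methylsulfonyl gives a similar step alongside 4-methylpiperazin-1-yl on the aromatic carbon.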